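This account rests on a few compounds, and the source may have more. Where it says the series, first, only, none or still open, it means among the compounds named here.

Measured compounds:
Compound 1 (`O=C(Nc1ccc2c(c1)B(O)OC2)c1ccccc1C(F)(F)F`): 2100 nM
Compound 2 (`O=C(Nc1ccc2c(c1)B(O)OC2)c1ccccc1Cl`): > 100000 nM
Compound 3 (`Cc1ccccc1C(=O)Nc1ccc2c(c1)B(O)OC2`): > 100000 nM

Among the measured compounds shown here, in a functional assay on PBMC cells (Homo sapiens) for inhibition, read by HTRF, with stated times of 15 min and 24 h (a higher number here means a weaker inhibitor, a lower number a stronger inhibitor), compound 1 gives 2100 nM and holds the only actual number of the three. Compound 2 reads > 100000 nM and this is a limit of the assay. Compound 3 reads > 100000 nM and this is also a limit of the assay. The measured steps are an at least 47-fold higher number from compound 1 to compound 2 (1.67 log units; beyond the scatter) with chloro in place of trifluoromethyl, and an at least 47-fold higher number from compound 1 to compound 3 (1.67 log units; beyond the scatter) with methyl in place of trifluoromethyl. Both are large. The step that the two limits leave unreadable from compound 2 to compound 3 adds nothing further.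

Compound 4 (`O=C(Nc1ccc2c(c1)B(O)OC2)c1cc(C(F)(F)F)ccc1C(F)(F)F`) retains the trifluoromethyl group of compound 1 and adds a second one. The change is trifluoromethyl in place of hydrogen on an aromatic carbon and it amounts to trifluoromethyl in place of hydrogen on an aromatic carbon, meta to a large group and para to a trifluoromethyl group. For the measured compounds named here, no measured step covers this carbon, so the steps above bear on it only indirectly. Since compound 4 keeps the group lost in an at least 47-fold higher number from compound 1 to compound 2 (1.67 log units; beyond the scatter) a collapse of that size is not expected. The expected result is a 1.4-fold higher number from compound 1 to compound 4 (0.15 log units; within the scatter) with little confidence in its direction. The estimate for compound 4 in this assay is 3000 nM with an expected range from 400 nM to 30000 nM at this stage.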

Compound 4, half-maximal inhibitory concentration: 2000 nM
Compound 4: middle estimate off by 1.5-fold (0.18 log units), on the high side; measured number inside the range.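

In this assay, trifluoromethyl in place of hydrogen on the aromatic carbon meta to a large group and para to a trifluoromethyl group gives a 1.1-fold lower number from compound 1 to compound 4 (0.02 log units; within the scatter), so adding 4 heavy atoms at this carbon leaves the reading unchanged within the scatter. The earlier compounds shown here spoke only to the exchange of the trifluoromethyl group already present, with chloro giving an at least 47-fold higher number from compound 1 to compound 2 (1.67 log units; beyond the scatter) and methyl giving an at least 47-fold higher number from compound 1 to compound 3 (1.67 log units; beyond the scatter). Among the four compounds shown, the large steps therefore belong to the loss of that trifluoromethyl group, while this second carbon is the first place in the series where a change gives no readable shift, though that rests on one group at one carbon.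

The compounds shown leave open whether an amine or a carboxylic acid on this carbon would also leave the reading flat, and whether chloro or methyl could be rescued by any group here. The step between the chloro and methyl compounds, compound 2 and compound 3, cannot be read: the limit of > 100000 nM in this assay, at which 2 of the 4 values shown sit.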